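A Pyrrolidinyl Pyridine Variant of the Thiazole Acid Series

This account rests on a few compounds, and the source may have more. Where it says the series, first, only, none or still open, it means among the compounds named here.

Among the three measured compounds, compound 3 `Cc1cc(-c2nc(C(c3ccc(F)cc3)c3ccc(F)cc3)sc2CC(=O)O)ccn1` stands strongest in an in vitro functional assay on HEK285-7 cells for antagonist activity at prostaglandin D2 receptor 2 (Homo sapiens), read by BRET and beta-arrestin recruitment; a higher number here means a weaker inhibitor, a lower number a stronger inhibitor: compound 3 gives 53 nM. Compound 1 `O=C(O)Cc1sc(C(c2ccc(F)cc2)c2ccc(F)cc2)nc1-c1cc(F)cc(F)c1` gives 340 nM in this assay, and compound 2 `N#Cc1cc(-c2nc(C(c3ccc(F)cc3)c3ccc(F)cc3)sc2CC(=O)O)ccc1F` gives 520 nM. The steps to compound 3 are a 6.4-fold lower number from compound 1 to compound 3 (0.81 log units; beyond the scatter) and a 9.8-fold lower number from compound 2 to compound 3 (0.99 log units; beyond the scatter), whereas between the two weaker compounds there is a 1.5-fold higher number from compound 1 to compound 2 (0.18 log units; within the scatter).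

Compound 4 `O=C(O)Cc1sc(C(c2ccc(F)cc2)c2ccc(F)cc2)nc1-c1ccnc(N2CCCC2)c1` differs from compound 3 in one place: pyrrolidin-1-yl in place of methyl on an aromatic carbon. Going by the values given here, no measured step bears directly on this change. The steps leading to compound 3 each exchange the whole aryl group on the shared core, and none of the three measured compounds alters a substituent on the 2-methylpyridin-4-yl ring while keeping that ring. Among the compounds with values here, the data therefore give no direction for the replacement of methyl by pyrrolidin-1-yl, and the only anchor is the value of compound 3.

On that basis compound 4 is expected to stay near compound 3, with a step of a 1.7-fold higher number from compound 3 to compound 4 (0.23 log units; within the scatter) in this assay and a broad uncertainty in either direction. The estimate for compound 4 is 90 nM, with a range from 25 nM to 350 nM.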

Compound 4, half-maximal inhibitory concentration: > 100000 nM
Compound 4: a limit, no number; the forecaster's own chance of this, stated with the estimate: 3%; at least 1100-fold (3.04 log units) between middle value and limit.
By their numbers in this assay, from the lowest: compound 3; then compounds 1 and 2 (each within the scatter of the next). At a limit, above all of these: compound 4.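

The reading for compound 4 is a limit of the assay and not a number: the limit of > 100000 nM in this assay, at which 1 of the 4 values shown sits.

This shows that the position on the aromatic carbon next to the ring nitrogen does not accept every substituent: with pyrrolidin-1-yl in place of methyl there is an at least 1800-fold higher number from compound 3 to compound 4 (3.27 log units; beyond the scatter), so the activity of compound 3 belongs to the 2-methylpyridin-4-yl group and is not carried by the pyridine ring alone. Going by these compounds alone, the 2-(pyrrolidin-1-yl)pyridin-4-yl group also falls behind both phenyl groups, with an at least 290-fold higher number from compound 1 to compound 4 (2.46 log units; beyond the scatter) and an at least 190-fold higher number from compound 2 to compound 4 (2.28 log units; beyond the scatter), so this one substituent change outweighs the exchanges of the whole aryl group that the earlier compounds covered.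

The compounds shown do not separate the contribution of the pyrrolidine ring from that of the nitrogen attached to the pyridine, and an open-chain dimethylamino group or an all-carbon cyclopentyl group at this carbon would bear on that question. They also leave open whether an amino group, a methoxy group or plain hydrogen in place of methyl would stay close to compound 3, at 53 nM in this assay.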